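A few compounds are considered here, and "the series" means these few. Any claim that something is new, unique, unknown or untested is made for them only; others in the source may bear on it.

Measured so far:
compound 1, `CCOC(=O)C[C@H]1[C@@H](O[Si](C)(C)C(C)(C)C)[C@H](n2cnc3c(NC(=O)Nc4ccccc4)ncnc32)O[C@@H]1COC(=O)NC`: 4.59 nM
compound 2, `CNC(=O)NC[C@H]1O[C@@H](n2cnc3c(NC(=O)Nc4ccccc4)ncnc32)[C@H](O[Si](C)(C)C(C)(C)C)[C@@H]1CC(=O)N(C)OC`: > 100 nM

Compound 1 sits at the strong end of the pair in a functional assay on SW-620 cells (Homo sapiens) for antiproliferative activity (a higher number here means a weaker inhibitor of growth, a lower number a stronger inhibitor of growth), where compound 1 gives 4.59 nM. For compound 2 this assay reports only a limit, > 100 nM, so no number for compound 2 is available and the limit of > 100 nM in this assay, at which 1 of the 2 values shown sits, marks where it sits. Among the measured compounds shown here, no step between measured compounds is recorded, and only these two values exist; compound 1 and compound 2 differ at more than one place, so what the two values show is left as it stands.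

Compound 3, `CCOC(=O)C[C@H]1[C@@H](O[Si](C)(C)C(C)(C)C)[C@H](n2cnc3c(NC(=O)Nc4ccccc4)ncnc32)O[C@@H]1CNC(=O)NC`, differs from compound 2 in one place: ethoxy in place of methoxy(methyl)amino on a carbonyl carbon. Compound 3 carries the same (ethoxycarbonyl)methyl group as compound 1 and the same methyl urea as compound 2. Since compound 2 stands only at a limit, the step to compound 3 is expected to run toward stronger inhibition, as an at least 5.0-fold lower number from compound 2 to compound 3 (0.69 log units; beyond the scatter), and likely beyond the scatter, though the size is uncertain. The estimate for compound 3 in this assay is 20 nM, within the range 4 nM to 150 nM.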

Compound 3, concentration for 50% growth inhibition: 4.8 nM
Compound 3: middle estimate off by 4.2-fold (0.62 log units), on the high side; the measured number falls inside the stated range.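

In this assay, the carbonyl carbon whose other neighbour is a saturated chain carbon proves sensitive to its substituent: with the methyl urea held fixed, ethoxy in place of methoxy(methyl)amino gives an at least 20-fold lower number from compound 2 to compound 3 (1.31 log units; beyond the scatter). The size of this step has only a lower bound, as compound 2 is reported only as a limit: the limit of > 100 nM in this assay, at which 1 of the 3 values shown sits. With ethoxy held fixed, (methylcarbamoyl)amino in place of (methylcarbamoyl)oxy on the saturated chain carbon bound to a saturated ring carbon gives a 1.0-fold higher number from compound 1 to compound 3 (0.02 log units; within the scatter), so this second change leaves the read-out unchanged within the scatter.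

On these data alone, how a carboxylic acid or a methylamino group on the same carbonyl carbon would read in this assay remains open. Also open, as far as these compounds go, is whether a longer chain can replace the ethyl of the ethoxy group.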